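Anilide-to-benzylamide switch in the pyridyl-thiadiazole series

The source may report more compounds than this note shows. Statements on the series, on what has been measured and on what is new or still open speak of the compounds shown alone.

Compound 1 `O=C(CCSc1nnc(-c2ccncc2)s1)Nc1ccc(Cl)cc1` gives 7260 nM in an ADME assay on HepG2 cells (Homo sapiens) for cytotoxicity, with a stated time of 3 days; on this read-out higher numbers stand for lower toxicity in this test and lower numbers for higher toxicity in this test. Compound 2 `O=C(CCSc1nnc(-c2ccncc2)s1)Nc1ccccc1Cl` differs only at the amide-type nitrogen, carrying 2-chlorophenyl in place of 4-chlorophenyl. For compound 2 this assay reports only a limit, > 50000 nM. The step is therefore an at least 6.8-fold higher number from compound 1 to compound 2 (0.83 log units; beyond the scatter), and it is bounded by the limit of > 50000 nM in this assay, at which 1 of the 2 values shown sits, rather than by a number. Compound 2 thus stands at the upper edge of what this assay can resolve, with no value inside the range.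

Compound 3 `O=C(CCSc1nnc(-c2ccncc2)s1)NCc1ccccc1` is the next variation at the same position: benzyl in place of 2-chlorophenyl on an amide-type nitrogen. Within the data shown here, no measured step covers this change; the only step on record, from compound 1 to compound 2, moved one chlorophenyl for another and reached the limit. With compound 2 already at the limit, the step in this assay from compound 2 to compound 3 cannot be placed by comparison; the expectation is a step near an at least 1.2-fold lower number from compound 2 to compound 3 (0.09 log units; that floor lies within the scatter), which is to say no clear movement. Compound 3 is expected to give about 40000 nM, within 12000 nM to 100000 nM.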

Compound 3, half-maximal cytotoxic concentration: 14000 nM
Compound 3: middle estimate off by 2.9-fold (0.46 log units), on the high side; the measured number falls inside the stated range.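

In this assay, benzyl on the amide-type nitrogen does not keep the reading of the 2-chlorophenyl anilide: the change gives an at least 3.5-fold lower number from compound 2 to compound 3 (0.55 log units; beyond the scatter), so the series' highest reading so far does not carry over to every replacement at this position. On these data alone, the true size of that step stays unknown, since one end of it rests on an assay limit rather than a number: the limit of > 50000 nM in this assay, at which 1 of the 3 values shown sits. Against the 4-chlorophenyl anilide, the same switch gives a 1.9-fold higher number from compound 1 to compound 3 (0.29 log units; within the scatter), so benzyl and 4-chlorophenyl cannot be told apart on this read-out, and the anilide-to-benzylamide switch alone does not set a direction, with the outcome depending on which anilide serves as the reference.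

The compounds shown leave open whether the separation of the 2-chlorophenyl anilide from the other two belongs to the chlorine or to the directly attached ring, a question that an unsubstituted phenyl and a 2-chlorobenzyl on the same nitrogen would help to divide. As far as these compounds go, how the reading responds to a longer chain such as 2-phenylethyl at this position also remains open, as does any change made elsewhere on the shared core.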